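This account rests on a few compounds, and the source may have more. Where it says the series, first, only, none or still open, it means among the compounds named here.

Measured so far:
- compound 1, `O=C(O)/C=C/c1ccc2noc(-c3ccc(Oc4ccccc4)cc3)c2c1`: 94 nM
- compound 2, `CNC(=O)c1ccc2noc(-c3ccccc3)c2c1`: 2120 nM
- compound 3, `O=C(O)c1ccc2noc(-c3ccc(Cc4ccccc4)cc3)c2c1`: 65 nM

These three numbers come from an assay for inhibition of inositol hexakisphosphate kinase 2 (Homo sapiens), read by colorimetric assay, coupled enzyme assay and malachite green, with a stated time of 120 min, in the presence of a further agent that is not named here; a higher number here means a weaker inhibitor, a lower number a stronger inhibitor. Compound 3 has the lowest number of the three. Compound 1 sits close to it, within the usual scatter, so no order between compound 3 and compound 1 can be read. Compound 2 lies well beyond the scatter on the weaker side; compound 2 carries no acid on the shared core and no group on its pendant ring, so it cannot tell what either change alone does.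

The step from compound 3 to compound 4, `CC(C)NC(=O)c1ccc(-c2onc3ccc(C(=O)O)cc23)cc1`, is isopropylcarbamoyl in place of benzyl on an aromatic carbon. For the measured compounds named here, no measured pair separates this change, so any expectation rests on the observation that both compound 1 and compound 3 carry a large group at that place and give the two low numbers. Dropping the aromatic ring from that group while keeping the acid is expected to cost some potency, but the acid on the core should hold the number well away from that of compound 2. The estimated step from compound 3 to compound 4 in this assay is a 3.1-fold higher number from compound 3 to compound 4 (0.49 log units; beyond the scatter). Compound 4 is estimated to give 200 nM in this assay, within a range from 60 nM to 700 nM.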

Compound 4, half-maximal inhibitory concentration: 350 nM
Compound 4: middle estimate off by 1.8-fold (0.24 log units), on the low side; the measured number falls inside the stated range.
By their numbers in this assay, from the lowest: compounds 3 and 1 (each within the scatter of the next); then compound 4; then compound 2.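

In this assay, for the compounds shown here, isopropylcarbamoyl in place of benzyl on the aromatic carbon para to a large group gives a 5.4-fold higher number from compound 3 to compound 4 (0.73 log units; beyond the scatter), the first step that changes a single place. The position therefore does not accept any group of similar size: the shared core and its carboxylic acid stay the same, and a group of nearly the same heavy-atom count gives a weaker inhibitor. The change removes the aromatic ring of benzyl and introduces the amide together, so this step cannot assign the loss to either alone.

A benzylcarbamoyl group or a plain isopropyl group at this place would separate those two changes. Nothing measured here explains the loss of potency.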